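The compounds below may be only part of what the source reports. "The series", "measured", "known", "first", "only" and "open" are said of these compounds alone.

Measured so far in a functional assay on the whole organism (Cavia porcellus) with Rattus norvegicus as the target; on this read-out lower numbers stand for an effect already at smaller amounts and higher numbers for an effect only at larger amounts of compound:
compound 1 `O=c1onc2n1C=CS[C@@]2(O)c1ccc(Cl)cc1`: 245000000 nM
compound 2 `CC1=C(C)n2c(noc2=O)[C@](O)(c2ccc(Cl)cc2)S1`: 705000000 nM
compound 3 `CC1=CS[C@@](O)(c2cccc(C)c2)c2noc(=O)n21`: 719000000 nM

Compound 3 stands at the high end of these numbers, together with compound 2, and the two values lie within the scatter of each other. Compound 1 has a lower number than compound 3, and that gap lies beyond the scatter.

The next compound to be read is compound 4 `CC1=CS[C@@](O)(c2ccccc2)c2noc(=O)n21`, which keeps the shared core of compound 3 and differs from it in one place: hydrogen in place of methyl on an aromatic carbon. This puts hydrogen in place of methyl on an aromatic carbon. Among the compounds with values here, no two measured compounds differ in only one place, so the series gives no direct measure of this change.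

Within the data shown here, the only guide is the span of the series, from compound 1 at 245000000 nM to compound 3 at 719000000 nM. On that basis, no step beyond the scatter is expected in this assay, with at most a slight drift toward a lower number. The expected move is a 1.3-fold lower number from compound 3 to compound 4 (0.12 log units; within the scatter), which is an estimate and stays within the scatter. For compound 4 the estimated value is 550000000 nM, with an expected range of 220000000 nM to 1300000000 nM.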

Compound 4, half-maximal effective concentration: 152000000 nM
Estimate against measurement, compound 4: 3.6-fold (0.56 log units) above, outside the stated range (below it).
By their numbers in this assay, from the lowest: compounds 4 and 1 (each within the scatter of the next); then compounds 2 and 3 (each within the scatter of the next).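

In this assay the exchange of methyl for hydrogen on an aromatic carbon of the six-membered aromatic ring, meta to a large group, comes with a 4.7-fold lower number from compound 3 to compound 4 (0.67 log units; beyond the scatter) and gives the series its first reading of a change in one place. This position is therefore not indifferent to what it carries: the loss of a single carbon is enough to move the read-out beyond the scatter, and the compound without the methyl shows its effect at smaller amounts. Nothing at hand explains this step or ties it to any property of the methyl group.

From the compounds shown here alone, with only methyl and hydrogen compared at this place, a single pair sets the direction, and it remains open how a methoxy group, an amine, a carboxylic acid or a longer chain in the same place would read. Within the data shown here, it is also open whether the same exchange gives a step of similar size on the core of compound 1 or the core of compound 2, where no such pair is at hand.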